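A few compounds are considered here, and "the series" means these few. Any claim that something is new, unique, unknown or untested is made for them only; others in the source may bear on it.

Three compounds have been measured in an ADME assay on HepG2 cells (Homo sapiens) for cytotoxicity, read by luminescence, CellTiter-Glo and ATP content, with a stated time of 72 h; a higher number here means that more compound is needed for the effect, a lower number that less compound is needed:
compound 1 `COc1cccc(CNCCCNc2ccnc3cc(-c4ccc(C(F)(F)F)cc4)ccc23)c1O`, 2210 nM;
compound 2 `CCC(CC)c1ccc2c(NCCCNCc3cccc(OC)c3O)ccnc2c1`, 410 nM;
compound 3 `COc1cccc(CNCCCNc2ccnc3cc(Cc4ccc(F)cc4)ccc23)c1O`, 4780 nM.

Compound 3 gives the highest number of the three in this assay, so the most compound is needed for the effect. Its nearest neighbour is compound 1: a 2.2-fold higher number from compound 1 to compound 3 (0.34 log units; beyond the scatter). The furthest is compound 2: a 12-fold higher number from compound 2 to compound 3 (1.07 log units; beyond the scatter).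

Compound 4 `COc1cccc(CNCCCNc2ccnc3cc(Oc4cccc(N(C)C)c4)ccc23)c1O` is not yet measured. It differs from compound 3 in one place: 3-(dimethylamino)phenoxy in place of 4-fluorobenzyl on an aromatic carbon. Among the measured compounds shown here, no measured step exchanges a group for an aryloxy group, so the comparison is indirect. The steps at this position are a 2.2-fold higher number from compound 1 to compound 3 (0.34 log units; beyond the scatter) and a 12-fold higher number from compound 2 to compound 3 (1.07 log units; beyond the scatter), with a 5.4-fold lower number from compound 1 to compound 2 (0.73 log units; beyond the scatter) between the other pair; together they show that the group on this aromatic carbon moves the number markedly, the pentan-3-yl giving the lowest and the 4-fluorobenzyl the highest. For the measured compounds named here, because compound 1 gives 2210 nM with an aromatic ring joined directly to the core, compound 4 is expected to land nearer that figure than the one for compound 2. The step expected for compound 4 is a 1.6-fold lower number from compound 3 to compound 4 (0.20 log units; within the scatter), a modest move downward or none beyond the scatter. Compound 4 is therefore estimated at 3000 nM, within 1200 nM to 8000 nM.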

Compound 4, half-maximal effective concentration: 7300 nM
The estimate for compound 4 lay 2.4-fold (0.39 log units) below the measured number; the measured number falls inside the stated range.
By their numbers in this assay, from the lowest: compound 2; then compound 1; then compounds 3 and 4 (each within the scatter of the next).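

In this assay, an aryloxy group on this aromatic carbon cannot be told apart from 4-fluorobenzyl, with a 1.5-fold higher number from compound 3 to compound 4 (0.18 log units; within the scatter). Both groups hold their ring one atom away from the shared core, and 3-(dimethylamino)phenoxy stays well clear of the other two groups, with a 3.3-fold higher number from compound 1 to compound 4 (0.52 log units; beyond the scatter) and an 18-fold higher number from compound 2 to compound 4 (1.25 log units; beyond the scatter). Across these four compounds, then, the ring held one atom away goes with the highest numbers, and no compound shown goes against this, though nothing measured here accounts for it.

The compounds shown leave open whether the dimethylamino group contributes to the number at all, or whether the oxygen link alone is enough. A plain phenoxy group, or a carboxylic acid in place of the dimethylamino group on the same ring, would separate the two.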